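Methyl in place of chloro: compound 3 to compound 4

A few compounds are considered here, and "the series" means these few. Any claim that something is new, unique, unknown or untested is made for them only; others in the source may bear on it.

Compound 1 `Cc1cc(F)ccc1Nc1ncc(C(F)(F)F)c(N2Cc3cccc(N(C)S(C)(=O)=O)c3C2)n1`: 16800 nM
Compound 2 `Cc1cc(C)cc(Nc2ncc(C(F)(F)F)c(N3Cc4cccc(N(C)S(C)(=O)=O)c4C3)n2)c1`: > 30000 nM (a limit)
Compound 3 `Cc1cc(Cl)ccc1Nc1ncc(C(F)(F)F)c(N2Cc3cccc(N(C)S(C)(=O)=O)c3C2)n1`: 19600 nM

Within the data shown here, in a functional assay on HepG2 cells (Homo sapiens) for antiproliferative activity, read by spectrophotometry, with a stated time of 2 days (a higher number here means a weaker inhibitor of growth, a lower number a stronger inhibitor of growth), compound 3 gives 19600 nM, within the scatter of the one other numeric value, that of compound 1. Compound 4 `Cc1ccc(Nc2ncc(C(F)(F)F)c(N3Cc4cccc(N(C)S(C)(=O)=O)c4C3)n2)c(C)c1` differs from it by methyl in place of chloro on an aromatic carbon, para to a large group. The closest measured change is small: a 1.2-fold higher number from compound 1 to compound 3 (0.07 log units; within the scatter). The aryl swap an at least 1.5-fold lower number from compound 2 to compound 3 (0.18 log units; that floor lies within the scatter) gives only a floor, as does an at least 1.7-fold higher number from compound 1 to compound 2 (0.25 log units; that floor lies within the scatter). On the size of these steps, no step beyond the scatter is expected in this assay. The expected step is a 1.1-fold higher number from compound 3 to compound 4 (0.03 log units; within the scatter). For compound 4 the estimated value is 21000 nM, with an expected range of 11000 nM to 30000 nM.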

Compound 4, concentration for 50% growth inhibition: 19100 nM
The estimate for compound 4 lay 1.1-fold (0.04 log units) above the measured number; the range from low to high includes it.
By their numbers in this assay, from the lowest: compounds 1, 4 and 3 (each within the scatter of the next). At a limit, above all of these: compound 2.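

In this assay, the aromatic carbon para to a large group now carries chloro, fluoro or methyl with no change beyond the scatter (a 1.0-fold lower number from compound 3 to compound 4 (0.01 log units; within the scatter); a 1.1-fold higher number from compound 1 to compound 4 (0.06 log units; within the scatter)). Methyl therefore reads the same here as both halogens in compounds 1, 3 and 4. Compound 2 is a limit, so its step (an at least 1.5-fold lower number from compound 2 to compound 4 (0.19 log units; that floor lies within the scatter)) gives only a floor: the limit of > 30000 nM in this assay, at which 1 of the 4 values shown sits.

As far as these compounds go, whether an amine, a carboxylic acid or a longer chain at this position would move the number beyond the scatter stays open.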